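Moving a Nitro Group Between Two Cytotoxicity Limits

A few compounds are considered here, and "the series" means these few. Any claim that something is new, unique, unknown or untested is made for them only; others in the source may bear on it.

Compound 1, `CCOc1ccc2c(c1)OC(c1ccccc1)C(c1ccccc1)C2=O`: in a functional assay on HL-60 cells (Homo sapiens) for cytotoxicity, read by MTT assay, with a stated time of 5 days (on this read-out lower numbers stand for higher toxicity in this test and higher numbers for lower toxicity in this test), compound 1 gives > 2500000 nM, which is a limit of the test and not a number.
Compound 2, `CCOc1ccc2c(c1)OC(c1cccc([N+](=O)[O-])c1)C(c1ccccc1)C2=O`: in this assay compound 2 gives > 2500000 nM, again a limit and not a number.

Among the measured compounds shown here, the only measured step, a step that the two limits leave unreadable from compound 1 to compound 2, cannot be sized, because both of its ends sit at the limit of > 2500000 nM in this assay, at which 2 of the 2 values shown sit. Compound 2 therefore stands only at that limit, with no number of its own in this assay. Compound 3, `CCOc1ccc2c(c1)OC(c1ccc([N+](=O)[O-])cc1)C(c1ccccc1)C2=O`, differs from compound 2 by 4-nitrophenyl in place of 3-nitrophenyl on a saturated ring carbon. For the measured compounds named here, no measured step speaks to this kind of rearrangement, and the one step known is unreadable. With compound 1 and compound 2 both at the limit, compound 3 is expected to show no step beyond the scatter, so the expected step that the limit leaves unreadable from compound 2 to compound 3 is close to none. Compound 3 is estimated at 3000000 nM, within 400000 nM to 25000000 nM, and most likely reported again as a limit.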

Compound 3, half-maximal cytotoxic concentration: 203000 nM
Estimate against measurement, compound 3: 15-fold (1.17 log units) above, and the stated range ends above it.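

Moving the nitro group, with 4-nitrophenyl in place of 3-nitrophenyl on the same saturated ring carbon, gives an at least 12-fold lower number from compound 2 to compound 3 (1.09 log units; beyond the scatter) in this assay, and a lower number here means higher toxicity in this test, so where the nitro group sits on this phenyl ring matters and not only whether it is present. Set against the unsubstituted phenyl, the 4-nitrophenyl gives an at least 12-fold lower number from compound 1 to compound 3 (1.09 log units; beyond the scatter), while the step from compound 1 to compound 2 cannot be read. Both readable sizes are minimums and not exact figures, because their starting compounds give only a limit: the limit of > 2500000 nM in this assay, at which 2 of the 3 values shown sit.

The compounds shown leave open whether this drop depends on the nitro group itself or would follow from other groups on that ring carbon's phenyl. An amine or a carboxylic acid in place of the nitro group of compound 3 would separate these two readings.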